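Chloro for Fluoro on the Sulfonyl Ring

This account rests on a few compounds, and the source may have more. Where it says the series, first, only, none or still open, it means among the compounds named here.

Measured so far:
compound 1, `O=C1/C(=C/c2ccccc2F)CN(S(=O)(=O)c2ccc(F)cc2)C/C1=C\c1ccccc1F`, 7700 nM
compound 2, `O=C1/C(=C/c2ccccc2F)CN(S(=O)(=O)c2ccc(Cl)cc2)C/C1=C\c1ccccc1F`, 4500 nM
compound 3, `O=C1/C(=C/c2ccc(F)cc2)CN(S(=O)(=O)c2ccc(F)cc2)C/C1=C\c1ccc(F)cc1`, 14700 nM

All three were tested in a functional assay on SMMC-7721 cells (Homo sapiens) for cytotoxicity, read by MTT assay, with a stated time of 24 h; on this read-out higher numbers stand for weaker inhibition and lower numbers for stronger inhibition. Compound 2 differs from compound 1 by chloro in place of fluoro on an aromatic carbon, and this gave a 1.7-fold lower number from compound 1 to compound 2 (0.23 log units; within the scatter). Compound 3 shares its atoms with compound 1 but joined differently; the difference between the two cores is not broken down here. Compound 3 and compound 1 give numbers within the usual scatter of each other, while compound 3 gives a higher number than compound 2.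

Compound 4, `O=C1/C(=C/c2ccc(F)cc2)CN(S(=O)(=O)c2ccc(Cl)cc2)C/C1=C\c1ccc(F)cc1`, has not yet been tested. It differs from compound 3 by chloro in place of fluoro on an aromatic carbon, the same change that turns compound 1 into compound 2. Within the data shown here, for compound 4 in this assay the step of a 1.6-fold lower number from compound 3 to compound 4 (0.21 log units; within the scatter) is expected, resting on the single earlier step of a 1.7-fold lower number from compound 1 to compound 2 (0.23 log units; within the scatter) seen on the other core, which was itself within the scatter. Compound 4 is therefore estimated at 9000 nM, with a likely range from 4000 nM to 20000 nM.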

Compound 4, half-maximal inhibitory concentration: 7000 nM
The estimate for compound 4 lay 1.3-fold (0.11 log units) above the measured number; measured number inside the range.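

Replacing fluoro with chloro on the sulfonyl ring gave a 2.1-fold lower number from compound 3 to compound 4 (0.32 log units; beyond the scatter) in this assay. Set beside the same replacement on the other core, the step carried over in direction and in size: the same change on two cores in this assay, a 1.7-fold lower number (0.23 log units; within the scatter) from compound 1 to compound 2 and a 2.1-fold lower number (0.32 log units; beyond the scatter) from compound 3 to compound 4, 1.2-fold (0.09 log units) apart, within the scatter of two such steps This agreement rests on only two pairs of compounds in a single cell assay, and one of the two steps lay within the scatter, so it supports carrying this change between these two cores but gives no general rule for other cores or other assays.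

The compounds shown leave open what a bromo group, a methoxy group or an amine would do in place of the chloro, on an aromatic carbon para to a large group. They also leave open whether the step would hold on a core carrying a nitrile or a methyl group where compounds 1 to 4 carry the fluoro groups outside the sulfonyl ring.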